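Removing the fluoro from compound 1: expected half-life

The compounds below may be only part of what the source reports. "The series", "measured", "known", "first", "only" and "open" are said of these compounds alone.

Compounds measured in a physicochemical assay for metabolic stability, read by HPLC, in phosphate buffer, at pH 7.4, tested at 10 uM (on this read-out higher numbers stand for a longer-lived compound and lower numbers for a shorter-lived compound), so far:
compound 1 `O=C(NCCCCc1ccccc1)n1c(=O)oc2cc(-c3ccc(F)cc3)ccc21`: > 5 h
compound 2 `O=C(NCCCCc1ccccc1)n1c(=O)oc2ccc(-c3ccccc3)cc21`: 4.93 h
compound 3 `O=C(c1ccc(Cl)cc1)c1ccc2c(c1)oc(=O)n2C(=O)NCCCCc1ccccc1`: 4.57 h

Compound 1 stands at the top of the numbers shown, but its value is a limit of this assay rather than a number (the limit of > 5 h in this assay, at which 1 of the 3 values shown sits). Compound 2, which carries its phenyl on a different carbon of the shared core, gives a number just under that limit, and compound 3 gives a number in the same region. For the measured compounds named here, the only measured step that starts from compound 1 is an at least 1.0-fold lower number from compound 1 to compound 3 (0.03 log units; that floor lies within the scatter), a change that leaves the half-life essentially where it was.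

Compound 4 `O=C(NCCCCc1ccccc1)n1c(=O)oc2cc(-c3ccccc3)ccc21` is not yet measured. It differs from compound 1 in one place: hydrogen in place of fluoro on an aromatic carbon. Going by the values given here, no measured step removes a fluoro, so the expectation rests on the neighbourhood of values: compound 1 at its limit, compound 2 and compound 3 within the scatter of each other just below it. The step of a number no higher from compound 1 to compound 4 (the limit leaves the size open) is therefore expected to be small, with no direction beyond the scatter. Compound 4 is estimated to give 5 h in this assay, between 3.5 h and 7 h, and it may well be reported only as a limit again.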

Compound 4, half-life: > 5 h
Compound 4 ended at the assay's limit; the forecaster's own chance of this, stated with the estimate: 50%; the middle value sits exactly at the limit.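

In this assay, taking the fluoro off leaves compound 4 at the same limit as compound 1, so the fluoro on this phenyl ring is not required for a half-life that reaches the limit. The size of this change cannot be read, because both compounds sit at that limit: the limit of > 5 h in this assay, at which 2 of the 4 values shown sit.

For the compounds shown here, the one step that can be read is an at least 1.0-fold higher number from compound 3 to compound 4 (0.03 log units; that floor lies within the scatter). It gives only a floor, so it does not show whether phenyl and (4-chlorophenyl)carbonyl truly differ at this position of the shared core.

The compounds shown leave open how long compound 1 and compound 4 actually last, and whether any group on this phenyl ring would bring the half-life down to a readable number. An amine or a carboxylic acid in place of the fluoro, or a longer chain in place of the one that ends in phenyl, would test how far this stability extends.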